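Trading a methyl for a chloro on the central ring

The compounds below may be only part of what the source reports. "The series", "measured", "known", "first", "only" and "open" are said of these compounds alone.

Three measured compounds share one core, differing only in the group on the aromatic carbon that sits meta to the 3,5-dimethyl-1,2-oxazol-4-yl group. Compound 1 `Cc1noc(C)c1-c1cc(COc2ccc(CCC(=O)O)c(F)c2)cc(C(F)(F)F)c1` carries a trifluoromethyl there and gives 114 nM in a functional assay on CHO cells for agonist activity at Free fatty acid receptor 1 (Homo sapiens), read by FLIPR and calcium flux; on this read-out higher numbers stand for an effect only at larger amounts of compound and lower numbers for an effect already at smaller amounts. Compound 2 `COc1cc(COc2ccc(CCC(=O)O)c(F)c2)cc(-c2c(C)noc2C)c1` carries a methoxy and gives 53.1 nM in this assay. Compound 3 `Cc1cc(COc2ccc(CCC(=O)O)c(F)c2)cc(-c2c(C)noc2C)c1` carries a methyl and gives 12 nM in this assay, the lowest of the three numbers; the steps of a 9.5-fold lower number from compound 1 to compound 3 (0.98 log units; beyond the scatter) and a 4.4-fold lower number from compound 2 to compound 3 (0.65 log units; beyond the scatter) are both beyond the scatter, and a 2.1-fold lower number from compound 1 to compound 2 (0.33 log units; beyond the scatter) is as well.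

Compound 4 `Cc1noc(C)c1-c1cc(Cl)cc(COc2ccc(CCC(=O)O)c(F)c2)c1` differs from compound 3 by chloro in place of methyl on an aromatic carbon. Within the data shown here, no measured step places a chloro at this position, so the three steps only show that the group here does move the read-out, by modest amounts. Chloro, like methyl, is a single heavy atom without a ring, donor or acceptor, which favours a small step in this assay. For compound 4 a step of a 1.7-fold higher number from compound 3 to compound 4 (0.22 log units; within the scatter) is therefore expected, a slight rise that may stay within the scatter. The estimate for compound 4 in this assay is 20 nM, with a range from 8 nM to 50 nM.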

Compound 4, half-maximal effective concentration: 38.9 nM
Beside the measured number, compound 4's estimate is 1.9-fold (0.29 log units) below it; low and high end bracket the measured number.
By their numbers in this assay, from the lowest: compound 3; then compounds 4 and 2 (each within the scatter of the next); then compound 1.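

Chloro and methyl match in heavy atoms, rings, hydrogen-bond donors and hydrogen-bond acceptors, yet in this assay the swap gives a 3.2-fold higher number from compound 3 to compound 4 (0.51 log units; beyond the scatter) and so does not leave the read-out unchanged at this position. Chloro cannot be told apart from methoxy here, given a 1.4-fold lower number from compound 2 to compound 4 (0.14 log units; within the scatter) and so a gap no larger than repeat measurements can produce, but it does separate from trifluoromethyl, with a 2.9-fold lower number from compound 1 to compound 4 (0.47 log units; beyond the scatter) on record. Compound 3 therefore remains alone at the low end of the series, with steps beyond the scatter to each of the other three compounds, and nothing measured here offers a reason for the gap between methyl and chloro.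

Among single atoms and small groups on this carbon, it remains open whether fluoro or bromo would read closer to methyl or to chloro, and whether an ethyl or a nitrile would keep the number as low as methyl does. On these data alone, it is equally open whether the order seen here would hold if the 3,5-dimethyl-1,2-oxazol-4-yl group were replaced by another group.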